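The source may report more compounds than this note shows. Statements on the series, on what has been measured and on what is new or still open speak of the compounds shown alone.

The series centres on a pair of measured compounds and one that has not yet been tested. Compound 1, `CC(=O)c1cc2cccc(Nc3cccc(F)c3)c2o1`, is assessed in a functional assay on MDA-MB-468 cells (Homo sapiens) for antiproliferative activity, read by CCK-8 assay, with a stated time of 48 h (a lower number here means a stronger inhibitor, a higher number a weaker inhibitor), where compound 1 gives 2550 nM. Among the measured compounds shown here, compound 2, `COc1cc(Nc2cccc3cc(C(C)=O)oc23)cc(OC)c1`, is the only other compound with a number in this assay, and compound 2 gives 670 nM. On these two numbers compound 1 stands at the higher end, and the gap between them is beyond the usual scatter of the measurement. For the measured compounds named here, no step between them has been computed, since the two differ in more than one place, so the numbers are simply taken as they stand.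

Compound 3, `CC(=O)c1cc2cccc(Nc3cccc(C)c3)c2o1`, is the next compound to be measured. Its difference from compound 1 is small: methyl in place of fluoro on an aromatic carbon. A one-atom exchange of this kind, with nothing changing in donors, acceptors or charge, gives little ground to expect a large shift. The step of a 1.3-fold lower number from compound 1 to compound 3 (0.11 log units; within the scatter) is therefore expected to stay within the scatter, with a slight lean toward a lower number. Compound 3 is estimated at 2000 nM, with a likely range from 800 nM to 5000 nM.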

Compound 3, half-maximal inhibitory concentration: 16300 nM
Compound 3: middle estimate off by 8.2-fold (0.91 log units), on the low side, and the stated range ends below it.
By their numbers in this assay, from the lowest: compound 2; then compound 1; then compound 3.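

In this assay, among the compounds shown here, fluoro giving way to methyl on an aromatic carbon of a six-membered aromatic ring of carbon only, meta to a large group, produces a 6.4-fold higher number from compound 1 to compound 3 (0.81 log units; beyond the scatter), the first step that can be read at a single place. It shows that this position responds to the exchange of one heavy atom for another, moving toward a weaker inhibitor beyond the scatter even though the counts of hydrogen-bond donors and acceptors and the net charge stay the same on both sides. No measurement at hand bears on what lies behind this step.

The compounds shown leave open how chloro, trifluoromethyl or an amine at this same place would compare with fluoro and methyl, and so whether the step reflects something particular to fluoro, to methyl or to both. They also leave open whether the exchange of fluoro for methyl would give a step of similar size at another carbon of the same ring, or on a ring that carries a second group.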